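Purine analogues with chloromethylbenzyl groups: removing one ring chlorine

The source may hold more compounds than are shown below. What is called first, only, known or untested is meant among the compounds shown, and "the series" means these compounds.

Compound 1 `ClCc1ccccc1Cn1cnc2c(Cl)ncnc21` gives 15900 nM in a functional assay on SK-OV-3 cells (Homo sapiens) for cytotoxicity, read by sulforhodamine B assay, with a stated time of 48 h; on this read-out higher numbers stand for weaker inhibition of growth and lower numbers for stronger inhibition of growth.
Compound 2 `ClCc1ccc(Cn2cnc3nc(Cl)nc(Cl)c32)cc1` gives 5010 nM in this assay.
Compound 3 `ClCc1cccc(Cn2cnc3c(Cl)nc(Cl)nc32)c1` is recorded as "not determined" (no result reported) in this assay, so no number is available for it.

Among the two compounds with a number, compound 2 has the lower value, and compound 1 stands a step away that is beyond the usual scatter of the assay. Compound 3 contributes no number to this comparison.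

Compound 4 `ClCc1ccc(Cn2cnc3ncnc(Cl)c32)cc1` differs from compound 2 in one place: hydrogen in place of chloro on an aromatic carbon. Going by the values given here, no pair of measured compounds isolates this single change, since compound 1 also carries its chloromethylbenzyl group in a different position on the benzene ring. Among the compounds with values here, with only this indirect comparison, the step from compound 2 to compound 4 is expected to be small, likely a modest move toward weaker growth inhibition and possibly within the scatter, giving a 1.6-fold higher number from compound 2 to compound 4 (0.20 log units; within the scatter). Compound 4 is therefore estimated at 8000 nM, with a range from 3000 nM to 25000 nM.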

Compound 4, concentration for total growth inhibition: 23400 nM
Beside the measured number, compound 4's estimate is 2.9-fold (0.47 log units) below it; measured number inside the range.
By their numbers in this assay, from the lowest: compound 2; then compounds 1 and 4 (each within the scatter of the next).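

In this assay, the chloro group on the aromatic carbon between two ring nitrogen atoms proves to count: replacing it with hydrogen gives a 4.7-fold higher number from compound 2 to compound 4 (0.67 log units; beyond the scatter), and growth inhibition weakens. The earlier compounds shown here could not show this, as no two of them differed in one place only. Here the other chloro group and the chloromethylbenzyl group stay the same, so the step belongs to this one change, though it rests on a single pair, and no measurement at hand explains it.

The compounds shown leave open how an amine or a longer chain on this same aromatic carbon would compare with chloro and hydrogen. They also leave open whether this change gives a similar step when the chloromethyl group sits elsewhere on the benzene ring.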